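Working notes: from compound 2 to compound 3

The source may report more compounds than this note shows. Statements on the series, on what has been measured and on what is new or still open speak of the compounds shown alone.

In a functional assay on HepG2 cells (Homo sapiens) for cytotoxicity, read by MTT assay, with a stated time of 72 h (a lower number here means a stronger inhibitor, a higher number a weaker inhibitor), compound 2 (`COc1ccc(/C=N/NC(=O)Nc2cc3c(Nc4ccc(F)c(Cl)c4)ncnc3cc2O[C@H]2CCOC2)c(OC)c1OC`) gives 29300 nM and stands level, within the scatter, with compound 1 (`O=C(N/N=C/c1cccc(Br)c1)Nc1cc2c(Nc3ccc(F)c(Cl)c3)ncnc2cc1O[C@H]1CCOC1`) at 32300 nM in the same read-out. Compound 3 (`O=C(N/N=C/c1ccc(O)c(Br)c1)Nc1cc2c(Nc3ccc(F)c(Cl)c3)ncnc2cc1O[C@H]1CCOC1`) carries the next change, with 3-bromo-4-hydroxyphenyl in place of 2,3,4-trimethoxyphenyl on a carbon with a double bond to nitrogen as the count: 3-bromo-4-hydroxyphenyl in place of 2,3,4-trimethoxyphenyl on a carbon with a double bond to nitrogen. Among the measured compounds shown here, one measured step bears on this place: 2,3,4-trimethoxyphenyl in place of 3-bromophenyl gave a 1.1-fold lower number from compound 1 to compound 2 (0.04 log units; within the scatter) and so no change beyond the scatter. For the measured compounds named here, no measured compound carries 3-bromo-4-hydroxyphenyl, so the range stays wide. No step beyond the scatter is expected in this assay here, and the expected step is a 1.2-fold lower number from compound 2 to compound 3 (0.09 log units; within the scatter) on this estimate. For compound 3 the estimated value is 24000 nM with 9000 nM to 48000 nM as the expected range.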

Compound 3, half-maximal inhibitory concentration: 660 nM
Compound 3: middle estimate off by 36-fold (1.56 log units), on the high side; measured number below the stated range.
By their numbers in this assay, from the lowest: compound 3; then compounds 2 and 1 (each within the scatter of the next).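

In this assay the place on the carbon with a double bond to nitrogen proves able to move the number, although compound 1 and compound 2 stood level: 3-bromo-4-hydroxyphenyl in place of 2,3,4-trimethoxyphenyl gives a 44-fold lower number from compound 2 to compound 3 (1.65 log units; beyond the scatter) and is a large step. The sharper reading comes from hydroxy in place of hydrogen on an aromatic carbon, which gives a 49-fold lower number from compound 1 to compound 3 (1.69 log units; beyond the scatter) as a large step with the bromine kept, so in this pair the bromine alone does not carry the drop. No measurement here bears on the cause of either step.

Open, as far as these compounds go, is whether the hydroxy keeps this step without the bromine. Also open, from the compounds shown here alone, is whether a methoxy, an amine or a carboxylic acid in its place would do the same.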